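Thiophene-carboxamide series: amide replaces benzyl on ring amine

A few compounds are considered here, and "the series" means these few. Any claim that something is new, unique, unknown or untested is made for them only; others in the source may bear on it.

Measured so far:
compound 1, `NC(=O)c1c(NC(=O)c2ccccc2Cl)sc2c1CCN(Cc1cc(Cl)cc(Cl)c1)C2`, 19600 nM
compound 2, `Cc1ccc(C(=O)Nc2sc3c(c2C(N)=O)CCN(Cc2c(Cl)cccc2Cl)C3)cc1`, 47400 nM

Both compounds were tested in a functional assay on HeLa cells (Homo sapiens) for antiproliferative activity, with a stated time of 24 h; on this read-out higher numbers stand for weaker inhibition and lower numbers for stronger inhibition. Compound 1 gives 19600 nM, compound 2 gives 47400 nM. Compound 1 holds the lower of the two numbers, and the gap to compound 2 lies beyond the usual scatter, so compound 1 is the stronger of the two on this read-out. Both numbers are high, so inhibition across the pair is weak.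

Compound 3, `NC(=O)c1c(NC(=O)c2ccccc2Cl)sc2c1CCN(C(=O)Nc1c(Cl)cccc1Cl)C2`, has not been tested in this assay. Relative to compound 1 the change is (2,6-dichlorophenyl)carbamoyl in place of 3,5-dichlorobenzyl on an amine nitrogen in a ring. The group that enters brings a hydrogen-bond donor and a hydrogen-bond acceptor where none stood before, and the nitrogen of the ring amine carries a carbonyl rather than a benzyl chain. Within the data shown here, no pair of measured compounds shows this kind of change, so there is no measured precedent to lean on. The step of a 1.3-fold higher number from compound 1 to compound 3 (0.11 log units; within the scatter) is expected to be small, with no direction that can be argued from the data, and may well sit within the scatter. Compound 3 is estimated at 25000 nM, in the range 6000 nM to 90000 nM.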

Compound 3, half-maximal inhibitory concentration: 27200 nM
The estimate for compound 3 lay 1.1-fold (0.04 log units) below the measured number, and the stated range covers the measured number.
By their numbers in this assay, from the lowest: compounds 1, 3 and 2 (each within the scatter of the next, the first and the last beyond it).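

In this assay, the amine nitrogen in the ring now has a measured step: (2,6-dichlorophenyl)carbamoyl in place of 3,5-dichlorobenzyl gives a 1.4-fold higher number from compound 1 to compound 3 (0.14 log units; within the scatter). Across this exchange, the hydrogen-bond donor, the hydrogen-bond acceptor and the carbonyl all enter without moving the number beyond the scatter, and inhibition stays weak for both compounds. No independent data bear on this result, so the step can be reported only as a read-out and cannot be explained.

From the compounds shown here alone, the step changes the link to the ring nitrogen and the placing of the two chlorines on the aromatic ring together, so the contribution of each remains open; a (3,5-dichlorophenyl)carbamoyl group at the same nitrogen would separate the two changes against compound 1. Also open is how far this position reaches in either direction, as neither a free ring amine nor a small acetyl group on that nitrogen is among the compounds shown.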